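Aryl tail variation on the shared oxazole ketone core

This account rests on a few compounds, and the source may have more. Where it says the series, first, only, none or still open, it means among the compounds named here.

Three compounds sharing the core of compound 1, `O=C(CCCCCCc1ccc(Cl)cc1)c1ncc(-c2ccccn2)o1`, differing only in the substituent on the terminal phenyl ring, have been run in an assay for inhibition of Fatty-acid amide hydrolase 1 (Rattus norvegicus); on this read-out higher numbers stand for weaker inhibition and lower numbers for stronger inhibition. Compound 1 gives 2.7 nM. Compound 2, `COc1ccc(CCCCCCC(=O)c2ncc(-c3ccccn3)o2)cc1`, gives 6.2 nM, and a 2.3-fold higher number from compound 1 to compound 2 (0.36 log units; beyond the scatter). Compound 3, `CS(=O)(=O)c1cccc(CCCCCCC(=O)c2ncc(-c3ccccn3)o2)c1`, gives 1.3 nM and so stands lowest of the three numbers; compound 1 is the nearest to it and compound 2 the furthest.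

Compound 4, `Nc1cccc(CCCCCCC(=O)c2ncc(-c3ccccn3)o2)c1`, has not yet been measured. It differs from compound 3 by amino in place of methylsulfonyl on an aromatic carbon. Within the data shown here, no measured step exchanges a methylsulfonyl group for an amino group, so no step bears directly on this change. Among the measured compounds shown here, the only measured step, from compound 1 to compound 2, swaps one substituent at the same place for another and is modest in size, and the values of compounds 1, 2 and 3 together span a narrow band. A change of comparable magnitude is therefore expected here, most plausibly toward a higher number in this assay, since compound 3 already holds the lowest value and the substituent entering is unlike any tested. The expected step is a 3.1-fold higher number from compound 3 to compound 4 (0.49 log units; beyond the scatter). For compound 4 the estimate in this assay is 4 nM, with a range from 1.3 nM to 12 nM.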

Compound 4, inhibition constant: 30 nM
Compound 4: middle estimate off by 7.5-fold (0.88 log units), on the low side, and the stated range ends below it.
By their numbers in this assay, from the lowest: compound 3; then compound 1; then compound 2; then compound 4.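

In this assay, among these compounds, the exchange of methylsulfonyl for amino on this aromatic carbon gives the largest step so far (a 23-fold higher number from compound 3 to compound 4 (1.36 log units; beyond the scatter)), showing that a change on the terminal phenyl ring can shift the number much further than the band set by compound 1, compound 2 and compound 3 suggested. Among the compounds shown here, compound 4 also has the highest number of the four, both against the methoxy compound (a 4.8-fold higher number from compound 2 to compound 4 (0.68 log units; beyond the scatter)) and against the chloro compound (an 11-fold higher number from compound 1 to compound 4 (1.05 log units; beyond the scatter)), but these two steps exchange a 4-substituted ring for 3-aminophenyl, so only the step from compound 3 holds the place on the ring fixed. No measurement at hand accounts for the rise or tells whether it tracks the loss of methylsulfonyl or the entry of amino.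

A nitrile, an amide or a carboxylic acid on the same aromatic carbon would show whether the amino group stands alone in raising the number or whether most replacements of methylsulfonyl do the same. As far as these compounds go, whether the step keeps its size with a shorter or longer chain also stays open.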